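The source may report more compounds than this note shows. Statements on the series, on what has been measured and on what is new or still open speak of the compounds shown alone.

Of the compounds shown here, three sharing one core have been measured in a functional assay on the whole organism with Mus musculus as the target; on this read-out higher numbers stand for an effect only at larger amounts of compound and lower numbers for an effect already at smaller amounts. There, compound 1 `Cn1nc(-c2ccc(F)cc2F)n(C)c1=S` gives 2.37 mg/kg, compound 2 `Cn1nc(-c2ccccc2F)n(C)c1=S` gives 0.23 mg/kg and compound 3 `Cn1nc(-c2ccccc2)n(C)c1=S` gives 0.13 mg/kg. The number for compound 2 thus lies within the scatter of that for compound 3 and well under that for compound 1. Compound 4 `Cn1nc(-c2c(F)cccc2F)n(C)c1=S` has not yet been measured. It departs from compound 2 by one change: fluoro in place of hydrogen on an aromatic carbon.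

Going by the values given here, two measured steps bear on this, both seen from the side where a fluoro group is removed. The step of a 10-fold lower number from compound 1 to compound 2 (1.01 log units; beyond the scatter) is large, while the step of a 1.8-fold lower number from compound 2 to compound 3 (0.25 log units; within the scatter) stays inside the scatter. Among the compounds with values here, no measured step covers fluoro on this particular carbon, and neither step shows a fluoro group going with a lower number. A modest rise is therefore expected in this assay. The estimated step is a 2.2-fold higher number from compound 2 to compound 4 (0.34 log units; beyond the scatter). The estimated value for compound 4 is 0.5 mg/kg, with an expected range from 0.13 mg/kg to 2 mg/kg.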

Compound 4, dose for half-maximal effect: 0.36 mg/kg
For compound 4 the middle estimate is 1.4-fold (0.14 log units) above the measured one, within the range that was stated.
By their numbers in this assay, from the lowest: compounds 3, 2 and 4 (each within the scatter of the next, the first and the last beyond it); then compound 1.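

On the carbon ortho to a group of 8 heavy atoms and meta to a fluoro group, fluoro in place of hydrogen gives in this assay a 1.6-fold higher number from compound 2 to compound 4 (0.19 log units; within the scatter), so a second fluoro is taken up here without a shift beyond the scatter. The large step of a 10-fold lower number from compound 1 to compound 2 (1.01 log units; beyond the scatter) therefore does not hold for every added fluoro on this ring: it belongs to another carbon, and compound 4 goes against any rule that a second fluoro as such raises the number. No measurement on these compounds accounts for the difference between the two carbons.

On these data alone, whether a chloro, methoxy or amine group on this same carbon would also stay within the scatter remains open. So does the effect of a longer chain in place of either methyl group on the shared core.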